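The compounds below may be only part of what the source reports. "The series", "measured", "known", "first", "only" and "open" are said of these compounds alone.

Compound 1 `COc1cc(-c2cc(/C=C/C(=O)c3ccc(N)cc3)[nH]n2)cc(OC)c1OC`: 8660 nM
Compound 2 `COc1ccc(-c2cc(/C=C/C(=O)c3ccc(N)cc3)[nH]n2)cc1OC`: 45700 nM

In a functional assay on UACC-257 cells (Homo sapiens) for inhibition, read by sulforhodamine B assay, with a stated time of 48 h (a higher number here means that more compound is tolerated, a lower number that less compound is tolerated), compound 1 gives 8660 nM, the lowest of the two numbers; compound 2 gives 45700 nM, and the step of a 5.3-fold higher number from compound 1 to compound 2 (0.72 log units; beyond the scatter) came from a hydrogen in place of methoxy on an aromatic carbon. Compound 3 `COc1cc(-c2cc(/C=C/C(=O)c3ccc(F)c(F)c3)[nH]n2)cc(OC)c1OC` differs from compound 1 by 3,4-difluorophenyl in place of 4-aminophenyl on a carbonyl carbon. Among the compounds with values here, no measured step touches that part of the shared core, so the one known step offers only a sense of scale. A modest rise is expected for compound 3, that is a 1.7-fold higher number from compound 1 to compound 3 (0.24 log units; within the scatter), giving an estimate of 15000 nM within 4000 nM to 50000 nM.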

Compound 3, concentration lethal to 50% of the cells: > 100000 nM
Compound 3 ended at the assay's limit; the forecaster's own chance of this, stated with the estimate: 10%; middle value at least 6.6-fold (0.82 log units) away from the limit.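

The group on the carbonyl carbon, untouched by the earlier pair, clearly counts in this assay: 3,4-difluorophenyl in place of 4-aminophenyl gives an at least 11-fold higher number from compound 1 to compound 3 (1.06 log units; beyond the scatter). Compound 3 reads > 100000 nM, which is a limit of the assay and not a number, so the true size of this step stays unknown: the limit of > 100000 nM in this assay, at which 1 of the 3 values shown sits.

Loss of the amino group and arrival of the fluorines happen together here, and the two cannot be told apart. As far as these compounds go, how a plain phenyl or a 4-hydroxyphenyl on that carbonyl carbon would behave remains open.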